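This account rests on a few compounds, and the source may have more. Where it says the series, first, only, none or still open, it means among the compounds named here.

In a physicochemical assay for solubility, read by HPLC, measured as thermodynamic solubility, with a stated time of 4 h, at pH 6.8 (a lower number here means a less soluble compound, a higher number a more soluble compound), compound 1 `Cc1cccc(Oc2ccc3nc(COc4cccc(C(=O)O)c4)n(C)c3c2)n1` gives 92 ug/mL, and compound 2 `Cc1cccnc1Oc1ccc2nc(COc3cccc(C(=O)O)c3)n(C)c2c1` gives 37 ug/mL, the lowest of the two numbers measured here. Going by the values given here, the one measured step, a 2.5-fold lower number from compound 1 to compound 2 (0.40 log units; beyond the scatter), moved only a methyl group around the pyridine ring. Compound 3 `Cn1c(COc2cccc(C(=O)O)c2)nc2ccc(Oc3ccc(F)cn3)cc21` differs from compound 2 by 5-fluoropyridin-2-yl in place of 3-methylpyridin-2-yl on an oxygen on an aromatic ring. Among the compounds with values here, no measured step exchanges a methyl for a fluorine in this way, so nothing here says which way this change should pull. Compound 3 is therefore expected to sit close to compound 2, a step of a 1.2-fold higher number from compound 2 to compound 3 (0.09 log units; within the scatter) that stays within the scatter, with an estimated solubility of 45 ug/mL in a range from 18 ug/mL to 110 ug/mL.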

Compound 3, solubility: 79 ug/mL
Beside the measured number, compound 3's estimate is 1.8-fold (0.24 log units) below it; low and high end bracket the measured number.
By their numbers in this assay, from the lowest: compound 2; then compounds 3 and 1 (each within the scatter of the next).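

In this assay, the change to 5-fluoropyridin-2-yl gives a 2.1-fold higher number from compound 2 to compound 3 (0.33 log units; beyond the scatter), so the group on this oxygen can move the number up as well as down. Set against the other pyridine, it gives a 1.2-fold lower number from compound 1 to compound 3 (0.07 log units; within the scatter), which leaves 3-methylpyridin-2-yl as the only one of the three groups that stands apart, with the lowest number. No measurement here offers an explanation for these numbers. The fluorine and the methyl also sit at different ring positions. 5-methylpyridin-2-yl would be needed to separate the two changes, and a pyridine carrying an amine remains an open case.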